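The source may hold more compounds than are shown below. What is called first, only, known or untested is meant among the compounds shown, and "the series" means these compounds.

Measured so far:
- compound 1 `Fc1ccc(Nc2cc3[nH]c(-c4cccc(C(F)(F)F)c4)nc3cn2)nc1`: >= 50000 nM (a limit)
- compound 2 `Fc1cnc(Nc2cc3[nH]c(-c4cccc(C(F)(F)F)c4)nc3cn2)c(F)c1`: >= 50000 nM (a limit)
- compound 3 `FC(F)(F)c1ccc(Nc2cc3[nH]c(C4CCOC4)nc3cn2)nc1`: 180000 nM (a number)

Among the compounds with values here, in a physicochemical assay for solubility, using the shake flask method, in simulated intestinal fluid, measured as kinetic solubility, with a stated time of 20 h, at pH 6.5 (a lower number here means a less soluble compound, a higher number a more soluble compound), compound 3 gives 180000 nM as the only actual number. Compound 1 and compound 2 both stand at the limit of >= 50000 nM in this assay, at which 2 of the 3 values shown sit, and cannot be ranked against it.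

The next compound is compound 4 `FC1(F)CCC(c2nc3cnc(Nc4ccc(C(F)(F)F)cn4)cc3[nH]2)CC1`, and the change is 4,4-difluorocyclohexyl in place of oxolan-3-yl on an aromatic carbon. Within the data shown here, the one measured step, a step that the two limits leave unreadable from compound 1 to compound 2, is a fluoro in place of hydrogen on an aromatic carbon. Among the measured compounds shown here, it has no readable size and is a different change, so no measured step bears directly on this one.

The expectation in this assay therefore rests on the structural change alone, with compound 3 at 180000 nM as the only anchor. The expected move is a 3.6-fold lower number from compound 3 to compound 4 (0.56 log units; beyond the scatter), towards a lower number and probably beyond the usual scatter, though with wide uncertainty. For compound 4 the estimated value is 50000 nM, with an expected range of 12000 nM to 150000 nM, and a reading reported only as a limit would be no surprise.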

Compound 4, solubility: 93000 nM
Compound 4: the middle estimate sits 1.9-fold (0.27 log units) below what was measured; measured number inside the range.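

In this assay, the position on an aromatic carbon between two ring nitrogen atoms now has its first readable step: 4,4-difluorocyclohexyl in place of oxolan-3-yl gives a 1.9-fold lower number from compound 3 to compound 4 (0.29 log units; within the scatter). This step trades a five-membered non-aromatic ring with 1 hetero atom and 1 hydrogen-bond acceptor for a six-membered non-aromatic ring of carbon only with 0 hydrogen-bond acceptors, and 5 heavy atoms become 8, yet the two compounds cannot be told apart in this read-out. The earlier compounds could not show this: the step between compound 1 and compound 2 cannot be read, and both values are limits rather than numbers: the limit of >= 50000 nM in this assay, at which 2 of the 4 values shown sit.

Within the data shown here, only two non-aromatic rings have been compared at this position, so this pair says nothing about how far the position tolerates change in general. Going by these compounds, whether an amine, a carboxylic acid or a longer chain on this carbon would give a step beyond the scatter stays open, as does the size of any step involving compound 1 or compound 2.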